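A few compounds are considered here, and "the series" means these few. Any claim that something is new, unique, unknown or untested is made for them only; others in the source may bear on it.

Compound 3 `CC(C)(CO)NCc1nc2c(OCC3CCCCC3)cccc2[nH]1` carries the shared core with a 1-(hydroxymethyl)-1-methylethyl group on the amine nitrogen. In an assay on cells for inhibition of interleukin-5 receptor subunit alpha (Mus musculus), read by WST assay, with a stated time of 48 h, in the presence of a further agent that is not named here (a higher number here means a weaker inhibitor, a lower number a stronger inhibitor), compound 3 gives 27500 nM, the higher of the two numbers in the set. Compound 2 `CCC(CO)NCc1nc2c(OCC3CCCCC3)cccc2[nH]1` gives 3500 nM in this assay. Compound 1 `OCCCCCNCc1nc2c(OCC3CCCCC3)cccc2[nH]1` reaches only a limit of this assay, > 30000 nM (the limit of > 30000 nM in this assay, at which 1 of the 3 values shown sits). Within the numbered pair, a 7.9-fold higher number from compound 2 to compound 3 (0.90 log units; beyond the scatter); the remaining steps, an at least 8.5-fold lower number from compound 1 to compound 2 (0.93 log units; beyond the scatter) and an at least 1.0-fold lower number from compound 1 to compound 3 (0.03 log units; that floor lies within the scatter), start from the limit and are bounded only on one side.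

Compound 4 `OCC(NCc1nc2c(OCC3CCCCC3)cccc2[nH]1)c1ccccc1` differs from compound 3 in one place: 2-hydroxy-1-phenylethyl in place of 1-(hydroxymethyl)-1-methylethyl on an amine nitrogen. The step that bears on it is a 7.9-fold higher number from compound 2 to compound 3 (0.90 log units; beyond the scatter), in which 1-(hydroxymethyl)-1-methylethyl in place of 1-(hydroxymethyl)propyl on the amine nitrogen read weaker. Going by the values given here, compound 4 returns to a 1-substituted hydroxyethyl pattern on that nitrogen, now with phenyl; no measured compound tests phenyl there, so the size is uncertain. The expectation is a modest fall in the number, a 5.5-fold lower number from compound 3 to compound 4 (0.74 log units; beyond the scatter), back toward the level of compound 2. Compound 4 is therefore estimated at 5000 nM in this assay, between 1200 nM and 25000 nM.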

Compound 4, half-maximal inhibitory concentration: 20000 nM
Estimate against measurement, compound 4: 4.0-fold (0.60 log units) below, and the stated range covers the measured number.
By their numbers in this assay, from the lowest: compound 2; then compounds 4 and 3 (each within the scatter of the next). At a limit, above all of these: compound 1.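

In this assay, phenyl in place of ethyl on a saturated chain carbon bound to an amine nitrogen and a saturated chain carbon gives a 5.7-fold higher number from compound 2 to compound 4 (0.76 log units; beyond the scatter), so the lower number seen with ethyl does not carry over to phenyl. The step of a 1.4-fold lower number from compound 3 to compound 4 (0.14 log units; within the scatter) lies within the scatter, so 2-hydroxy-1-phenylethyl and 1-(hydroxymethyl)-1-methylethyl on the amine nitrogen cannot be told apart here, and among the measured values only the 1-(hydroxymethyl)propyl group of compound 2 stands clear of the others. Compound 1 stands at a limit: the limit of > 30000 nM in this assay, at which 1 of the 4 values shown sits. The step of an at least 1.5-fold lower number from compound 1 to compound 4 (0.17 log units; that floor lies within the scatter) starts from that limit, so it is bounded on one side only and cannot be read.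

Open, on these data alone, is whether methyl or a longer chain on that carbon would give a number closer to that of compound 2. Also open, as far as these compounds go, is how a benzyl group there, or an amine in place of the hydroxyl, would read.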